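The compounds below may be only part of what the source reports. "The series", "measured", "known", "first", "only" and "open" are said of these compounds alone.

For the measured compounds named here, compound 1 `Cn1ncc2c(-c3ccc(F)cc3)cc(NNC(=O)Nc3cc(Cl)nc(OCCF)c3)nc21` is one of three compounds measured in an assay on isolated protein for binding affinity to sphingosine 1-phosphate receptor 2 (Homo sapiens), read by surface plasmon resonance (a lower number here means tighter binding, a higher number weaker binding), where compound 1 gives 2790 nM. That is the highest of the three numbers. Compound 2 `Cn1nc(C(F)(F)F)c2c(-c3ccccc3)cc(NNC(=O)Nc3cc(Cl)nc(Cl)c3)nc21` gives 940 nM in this assay, a lower number beyond the scatter, while compound 3 `CCCc1cc(NNC(=O)Nc2cc(Cl)nc(Cl)c2)nc2c1cnn2C` gives 1400 nM, which lies within the scatter of compound 1. Compound 4 `COc1cc(NC(=O)NNc2cc(-c3ccc(F)cc3)c3cnn(C)c3n2)cc(Cl)n1` has not yet been measured in this assay. It differs from compound 1 in one place: hydrogen in place of fluoromethyl on a saturated chain carbon bound to an oxygen on an aromatic ring. Going by the values given here, with no measured pair showing such a change, no step beyond the scatter is expected in this assay, in either direction. The step from compound 1 to compound 4 is estimated as a 1.1-fold higher number from compound 1 to compound 4 (0.03 log units; within the scatter). Compound 4 is therefore expected to give about 3000 nM in this assay, within a range from 1200 nM to 7500 nM.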

Compound 4, dissociation constant: 1650 nM
The estimate for compound 4 lay 1.8-fold (0.26 log units) above the measured number; measured number inside the range.
By their numbers in this assay, from the lowest: compounds 2, 3, 4 and 1 (each within the scatter of the next, the first and the last beyond it).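

For the compounds shown here, the change from 2-fluoroethoxy to methoxy gives the first measured pair at this position in this assay, with a 1.7-fold lower number from compound 1 to compound 4 (0.23 log units; within the scatter), a step within the scatter. With the rest of compound 1 held constant, removing the fluoromethyl therefore produces no reliable change in binding. No evidence here bears on the reason for this result.

As far as these compounds go, it remains open what an aminoethoxy group or a longer chain such as butoxy would give at this place. From the compounds shown here alone, it is also open whether the same change would read alike on a core carrying different groups elsewhere.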